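From Cyclopropyl to Ethoxy on the Carbonyl

This account rests on a few compounds, and the source may have more. Where it says the series, first, only, none or still open, it means among the compounds named here.

Three compounds share one core. Compound 2 `O=C(NN1CC=CCC1)C1CC1` gives the highest of the three numbers, 100% in a functional assay on the whole organism with Mus musculus as the target, in the writhing test, at a dose of 30 mg/kg by the subcutaneous route (a lower number here means less inhibition, a higher number more inhibition at the dose given (going by the name of the read-out)), though the other two lie within the scatter of it. Compound 3 `O=C(NN1CC=CCC1)C1CCCC1` gives 98% in this assay, and compound 1 `Cn1cccc1C(=O)NN1CC=CCC1` gives 90%. Compound 4 `CCOC(=O)NN1CC=CCC1` has not yet been tested in this assay. It differs from compound 2 by ethoxy in place of cyclopropyl on a carbonyl carbon. Among the compounds with values here, no step between measured compounds is known, so the data give no direct guide to this change. Because compound 2 gives 100% near the top of the scale, the expected step of a number 25 percentage points lower from compound 2 to compound 4 (beyond the scatter) is downward and moderate, with a wide margin of uncertainty. Compound 4 is estimated at 75%, with a range from 40% to 100%.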

Compound 4, a percentage reported as inhibition, in the whole organism at one dose (the size of the read-out at that dose, not a potency): 99%
Beside the measured number, compound 4's estimate is 24 percentage points below it; low and high end bracket the measured number.
By their numbers in this assay, from the lowest: compounds 1, 3, 4 and 2 (each within the scatter of the next).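

In this assay, replacing the ring with an open chain gives a number 1 percentage points lower from compound 2 to compound 4 (within the scatter). Every earlier group on this carbonyl carbon held a ring, whereas ethoxy holds none and brings a hydrogen-bond acceptor, so a ring is not needed there for a high reading at this dose. No measurement available here explains why the two groups read alike.

As far as these compounds go, whether an amine or a longer chain such as butoxy on this carbonyl carbon would keep the reading remains open. With readings this close to the top of the scale at a single dose, the compounds shown also leave any difference in potency between cyclopropyl and ethoxy unresolved.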